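This account rests on a few compounds, and the source may have more. Where it says the series, first, only, none or still open, it means among the compounds named here.

Measured so far:
compound 1 `CN1C(=S)[C@@H](NC(=O)c2nc(Cc3ccccc3)n(C3CCC3)n2)COc2ccccc21` — > 100000 nM
compound 2 `CN1C(=S)[C@@H](NC(=O)c2nc(Cc3ccccc3)n(C3CCCCC3)n2)COc2ccccc21` — > 100000 nM

In a toxicity assay on HT-29 cells (Homo sapiens) for cytotoxicity (on this read-out higher numbers stand for lower toxicity in this test and lower numbers for higher toxicity in this test), compound 1 gives > 100000 nM, which is a limit of the assay and not a number. In this assay compound 2 gives > 100000 nM, again a limit rather than a number. The step between them is a step that the two limits leave unreadable from compound 1 to compound 2, so its size cannot be read. Going by the values given here, compound 2 thus stands at the edge of what this assay reports, and the one other value shown sits at the same edge: the limit of > 100000 nM in this assay, at which 2 of the 2 values shown sit.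

Compound 3 `CN1C(=S)[C@@H](NC(=O)c2nc(Cc3ccccc3)n(C3CCNCC3)n2)COc2ccccc21` differs from compound 2 by piperidin-4-yl in place of cyclohexyl on an aromatic nitrogen. Among the compounds with values here, the only measured step, that from compound 1 to compound 2, bears on a change at the same place but is unreadable, so it gives no size or direction beyond the scatter to carry over. With both shown values at the limit, compound 3 is expected to come out at the limit as well, and the step of a number no higher from compound 2 to compound 3 (the limit leaves the size open) is expected to be unreadable in the same way. The estimate for compound 3 in this assay is 100000 nM, with a range from 30000 nM to 300000 nM.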

Compound 3, half-maximal cytotoxic concentration: > 100000 nM
Compound 3: a limit, no number; the forecaster's own chance of this, stated with the estimate: 80%; the middle value sits exactly at the limit.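

In this assay compound 3 gives > 100000 nM, a limit of the assay and not a number. No new step can be read among compound 1, compound 2 and compound 3, because all three stand at the same edge: the limit of > 100000 nM in this assay, at which 3 of the 3 values shown sit.

Going by these compounds, whether cyclobutyl, cyclohexyl and piperidin-4-yl on the aromatic nitrogen differ at all in this assay stays open.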